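Methyl for tert-butyl on the biaryl ring of compound 3

The source may hold more compounds than are shown below. What is called first, only, known or untested is meant among the compounds shown, and "the series" means these compounds.

Compound 3 `COc1ccc(CN2C(=O)C(=O)c3cc(-c4ccc(C(C)(C)C)cc4)ccc32)cc1` gives 4580 nM in a functional assay on HepG2 cells (Homo sapiens) for antiproliferative activity, read by MTT assay, with a stated time of 48 h (a higher number here means a weaker inhibitor, a lower number a stronger inhibitor), and stands second highest of three numbers. Its nearest neighbour is compound 1 `Cc1ccc(-c2ccc3c(c2)C(=O)C(=O)N3)cc1`, which gives 6000 nM in this assay, a gap within the scatter. Furthest away is compound 2 `COc1ccc(CN2C(=O)C(=O)c3cc(-c4ccc(OC)cc4)ccc32)cc1`, which gives 50 nM in this assay, and the single-point step from compound 2 to compound 3 is a 92-fold higher number from compound 2 to compound 3 (1.96 log units; beyond the scatter), so the group on that aromatic carbon para to the large group weighs heavily here.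

Compound 4 `COc1ccc(CN2C(=O)C(=O)c3cc(-c4ccc(C)cc4)ccc32)cc1` differs from compound 3 by methyl in place of tert-butyl on an aromatic carbon. For the measured compounds named here, no measured step covers methyl directly; compound 1 carries the same 4-methylphenyl but lacks the methoxybenzyl, and no step is given for that pair. Going by the values given here, the only bearing step, from compound 2 to compound 3, shows that replacing methoxy costs much. Methyl is neither group, so a move back toward compound 2 is expected but not the full way: the estimated step is a 5.1-fold lower number from compound 3 to compound 4 (0.71 log units; beyond the scatter), giving an expected 900 nM for compound 4, with a range of 150 nM to 4500 nM.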

Compound 4, half-maximal inhibitory concentration: > 10000 nM
Compound 4: no number, only a limit; the forecaster's own chance of this, stated with the estimate: 5%; middle value at least 11-fold (1.04 log units) from the limit.
By their numbers in this assay, from the lowest: compound 2; then compounds 3 and 1 (each within the scatter of the next). At a limit, above all of these: compound 4.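

Compound 4 has no number in this assay, only a limit: the limit of > 10000 nM in this assay, at which 1 of the 4 values shown sits.

Of the three groups seen on this aromatic carbon para to a large group, only methoxy goes with a low number, since tert-butyl gives a 92-fold higher number from compound 2 to compound 3 (1.96 log units; beyond the scatter) and methyl gives an at least 200-fold higher number from compound 2 to compound 4 (2.30 log units; beyond the scatter). Going from tert-butyl to methyl brings no move back toward the methoxy compound, but instead an at least 2.1-fold higher number from compound 3 to compound 4 (0.33 log units; beyond the scatter).

With the 4-methylphenyl in place, the effect of the 4-methoxybenzyl on the amide-type nitrogen stays unsettled, as the step reads an at least 1.6-fold higher number from compound 1 to compound 4 (0.22 log units; that floor lies within the scatter). Also open, from the compounds shown here alone, are the true sizes of the steps that end at the limit, and whether an ethoxy, a hydroxy or an amine on this carbon would keep the low number seen with methoxy.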